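This account rests on a few compounds, and the source may have more. Where it says the series, first, only, none or still open, it means among the compounds named here.

Series notes, cytotoxicity tolerance.

Compound 1 `O=c1[nH]cc(S(=O)(=O)Nc2cccc(-c3cn(-c4ccccc4Cl)nn3)c2)c(=O)[nH]1` and compound 2 `O=c1[nH]cc(S(=O)(=O)Nc2cccc(-c3cn(-c4cccc(Cl)c4)nn3)c2)c(=O)[nH]1` share a core and differ only in the aryl group on the triazole nitrogen. In an ADME assay on L02 cells (Homo sapiens) for cytotoxicity, read by MTT assay, with a stated time of 24 h (on this read-out higher numbers stand for lower toxicity in this test and lower numbers for higher toxicity in this test), compound 1 gives 11500 nM. In this assay compound 2 gives 8330 nM. The change from one to the other is 3-chlorophenyl in place of 2-chlorophenyl on an aromatic nitrogen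

The step it made was a 1.4-fold lower number from compound 1 to compound 2 (0.14 log units; within the scatter): the two numbers cannot be told apart on this read-out.

Compound 3 `O=c1[nH]cc(S(=O)(=O)Nc2ccc(-c3cn(-c4ccccc4Cl)nn3)cc2)c(=O)[nH]1` carries the 2-chlorophenyl of compound 1 on a core that is connected differently; the difference between the two cores is not broken down here. In this assay, going by the values given here, compound 3 gives 19300 nM, the highest of the three numbers so far, though the gap to compound 1 stays within the scatter and only the gap to compound 2 lies beyond it.

Compound 4 `O=c1[nH]cc(S(=O)(=O)Nc2ccc(-c3cn(-c4cccc(Cl)c4)nn3)cc2)c(=O)[nH]1` has not yet been measured. It stands to compound 3 as compound 2 stands to compound 1, and the change is the same one: 3-chlorophenyl in place of 2-chlorophenyl on an aromatic nitrogen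

Because compound 1 to compound 2 gave only a 1.4-fold lower number from compound 1 to compound 2 (0.14 log units; within the scatter), a step of the same small size is expected here, a 1.4-fold lower number from compound 3 to compound 4 (0.14 log units; within the scatter), and no reversal of direction is expected. In this assay compound 4 is therefore estimated at 14000 nM, with the expected range running from 7000 nM to 28000 nM; a result anywhere in that range would leave compound 4 and compound 3 within the scatter of each other.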

Compound 4, half-maximal cytotoxic concentration: 19000 nM
Estimate against measurement, compound 4: 1.4-fold (0.13 log units) below; the measured number falls inside the stated range.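

The step from 2-chlorophenyl to 3-chlorophenyl on the aromatic nitrogen, now on the core of compound 3, gave in this assay a 1.0-fold lower number from compound 3 to compound 4 (0.01 log units; within the scatter), so the two numbers cannot be told apart on this read-out. Set beside the step on the core of compound 1, it shows no difference between the two cores beyond the scatter: the same change on two cores in this assay, a 1.4-fold lower number (0.14 log units; within the scatter) from compound 1 to compound 2 and a 1.0-fold lower number (0.01 log units; within the scatter) from compound 3 to compound 4, 1.4-fold (0.13 log units) apart, within the scatter of two such steps This shows only that exchanging these two chlorophenyl groups left no readable change on either of the two cores; as neither step lies beyond the scatter, it shows no real effect being carried from one core to the other, and it says nothing about any further core.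

All four compounds shown carry a chlorophenyl group on the triazole nitrogen, so it remains open whether a different group there, such as an unsubstituted phenyl, a methoxyphenyl, or a phenyl bearing an amine or a carboxylic acid, would give a step beyond the scatter in this assay. As far as these compounds go, it also remains open whether such a step, if one appeared on one core, would recur on the other.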